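The source may report more compounds than this note shows. Statements on the series, on what has been measured and on what is new or still open speak of the compounds shown alone.

In a functional assay for activation of Alpha-1D adrenergic receptor (Homo sapiens), read by calcium flux (a higher number here means that more compound is needed for the effect, a lower number that less compound is needed), three compounds have been measured so far, and every one of them gives only a limit rather than a number. Compound 1 `CCN(CC)C(=O)c1ccccc1OCC1=NCCN1` carries a diethylamide on the shared core, and in this assay compound 1 gives < 5020 nM, a limit. Compound 2 `Cc1cccc(-c2ccccc2OCC2=NCCN2)n1` carries a methylpyridine on the same core, and in this assay compound 2 gives < 100000 nM, also a limit. Compound 3 `c1ccc(-c2ccncn2)c(OCC2=NCCN2)c1` carries a pyrimidin-4-yl group, and in this assay compound 3 gives < 100000 nM, likewise a limit. Compound 3 therefore stands at the limit of < 100000 nM in this assay, at which 2 of the 3 values shown sit. Compound 1 alone stands at the limit of < 5020 nM in this assay, at which 1 of the 3 values shown sits. Going by the values given here, no compound here offers a number that another could be compared against.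

Compound 4 `c1ccc(-c2ccsc2)c(OCC2=NCCN2)c1` differs from compound 3 in one place: thiophen-3-yl in place of pyrimidin-4-yl on an aromatic carbon. Among the compounds with values here, no measured pair shows what such a swap does in this assay, so the size and direction of the step are open; a small step or none beyond the scatter is as plausible as a larger one. Compound 4 is expected to land near 30000 nM, within 3000 nM to 100000 nM. The expected step is a step that the limit leaves unreadable from compound 3 to compound 4. A further limit rather than a number is considered quite likely.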

Compound 4, half-maximal effective concentration: 12.6 nM
Compound 4: the middle estimate sits 2400-fold (3.38 log units) above what was measured; measured number outside the range, below it.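

In this assay compound 3 gives < 100000 nM, which is a limit and not a number. Going by these compounds alone, compound 4 gives 12.6 nM, and no step from compound 3 to compound 4 can be read. The compounds shown leave open how large a step thiophen-3-yl in place of pyrimidin-4-yl brings.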